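A few compounds are considered here, and "the series" means these few. Any claim that something is new, unique, unknown or untested is made for them only; others in the source may bear on it.

Three analogues of one shared core have been read in a functional assay on HCT-116 cells (Homo sapiens) for inhibition, read by MTT assay, with a stated time of 48 h; on this read-out lower numbers stand for stronger inhibition and higher numbers for weaker inhibition. Compound 1 `C/C=C/C(=O)N(Cc1ccc(OC)c(OC)c1)c1cc(OC)c(OC)c(OC)c1` gives 32800 nM in this assay. Compound 2 `COc1ccc(CNc2cc(OC)c(OC)c(OC)c2)cc1Br`, which carries no carbonyl at the nitrogen, gives 48100 nM in this assay. Compound 3 `C#CC(=O)N(Cc1ccc(OC)c(O)c1)c1cc(OC)c(OC)c(OC)c1` gives 310 nM in this assay. On these numbers compound 3 stands lowest of the three; its gaps to compound 1 and to compound 2 both lie well beyond the usual scatter, so it is the strongest inhibitor of the set as measured.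

The next compound, compound 4 `C=CC(=O)N(Cc1ccc(OC)c(O)c1)c1cc(OC)c(OC)c(OC)c1`, keeps everything of compound 3 except one group at the carbonyl. The change is vinyl in place of ethynyl on a carbonyl carbon.

Among the measured compounds shown here, no pair among the measured compounds differs in a single place, so no measured step sets the scale for this change. For the measured compounds named here, the reading rests on compound 3 alone: the ethynylcarbonyl is the only carbonyl group among the three that sits beside a low number, and the vinylcarbonyl of compound 4 is untested. Since compound 3 gives 310 nM, a step of modest size toward a higher number is expected for a 2.3-fold higher number from compound 3 to compound 4 (0.35 log units; beyond the scatter), possibly not beyond the scatter. Compound 4 is therefore estimated at 700 nM in this assay, within a range from 150 nM to 3500 nM.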

Compound 4, half-maximal inhibitory concentration: 98 nM
Estimate against measurement, compound 4: 7.1-fold (0.85 log units) above; measured number outside the range, below it.
By their numbers in this assay, from the lowest: compound 4; then compound 3; then compounds 1 and 2 (each within the scatter of the next).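

In this assay, among the compounds shown here, the change at the carbonyl carbon gives a 3.2-fold lower number from compound 3 to compound 4 (0.50 log units; beyond the scatter) and is the first single-place step, modest in size but beyond the scatter. With the rest of compound 3 held fixed, the ethynyl group is thus not required for a low number at this position: a vinyl group, with the same count of heavy atoms and a double bond in place of the triple bond, reads lower, and the position responds to an exchange of this size. No measured data at hand bear on why the vinyl group reads lower.

Still open, going by these compounds, is whether the unsaturated bond matters at all, a point that an ethyl group on the same carbonyl carbon would settle, and whether this position tolerates anything larger, such as a longer chain or a vinyl group carrying a dimethylamino substituent. A single step also leaves open whether the same exchange would read the same way on a different substitution pattern of the shared core, for example with a methoxy group or a fluorine in place of the hydroxyl of compound 4.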